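Swapping Chlorine Positions on a Dichlorophenyl Group

The source may report more compounds than this note shows. Statements on the series, on what has been measured and on what is new or still open speak of the compounds shown alone.

Compound 1 `COc1cc(/C=C2\CN(C)C/C(=C\c3ccc(Cl)c(Cl)c3)C2=O)cc(OC)c1`: 9490 nM
Compound 2 `COc1cc(/C=C2\CN(C)C/C(=C\c3ccc(F)cc3)C2=O)cc(OC)c1OC`: 10300 nM
Compound 3 `COc1cc(/C=C2\CN(C)C/C(=C\c3ccc(Cl)cc3Cl)C2=O)cc(OC)c1OC`: > 20000 nM (a limit, not a number)

All three compounds were tested in a functional assay on K562 cells (Homo sapiens) for cytotoxicity, read by MTT assay, with a stated time of 24 h; a higher number here means a weaker inhibitor, a lower number a stronger inhibitor. Compound 3 stands at the limit of this assay: the limit of > 20000 nM in this assay, at which 1 of the 3 values shown sits.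

Compound 4 `COc1cc(/C=C2\CN(C)C/C(=C\c3ccc(Cl)c(Cl)c3)C2=O)cc(OC)c1OC` differs from compound 3 in one place: 3,4-dichlorophenyl in place of 2,4-dichlorophenyl on a double-bonded chain carbon bound to a double-bonded ring carbon. Among the measured compounds shown here, the only measured step at this place runs an at least 1.9-fold higher number from compound 2 to compound 3 (0.28 log units; that floor lies within the scatter), which does not clearly exceed the usual scatter. Compound 1 also carries 3,4-dichlorophenyl, with a slightly different remainder, and gives 9490 nM. A modest move towards a lower number is therefore expected, though with little certainty. The estimated step is an at least 1.8-fold lower number from compound 3 to compound 4 (0.25 log units; that floor lies within the scatter). For compound 4 the estimated value is 11000 nM, with an expected range of 5000 nM to 22000 nM.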

Compound 4, half-maximal inhibitory concentration: 16200 nM
Estimate against measurement, compound 4: 1.5-fold (0.17 log units) below, and the stated range covers the measured number.
By their numbers in this assay, from the lowest: compounds 1, 2 and 4 (each within the scatter of the next). At a limit, above all of these: compound 3.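

Moving the chlorines from 2,4-dichlorophenyl to 3,4-dichlorophenyl gives an at least 1.2-fold lower number from compound 3 to compound 4 (0.09 log units; that floor lies within the scatter), so this change has only a floor and no measured size. Compound 3 is a limit in this assay, not a number: the limit of > 20000 nM in this assay, at which 1 of the 4 values shown sits. The 3,4-dichlorophenyl group in place of 4-fluorophenyl gives a 1.6-fold higher number from compound 2 to compound 4 (0.20 log units; within the scatter), and methoxy in place of hydrogen on an aromatic carbon gives a 1.7-fold higher number from compound 1 to compound 4 (0.23 log units; within the scatter), so neither change clearly separates the compounds.

Going by these compounds, whether any group at this place can move the number beyond the scatter stays open. An amine or a carboxylic acid on the phenyl ring would test this.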